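A few compounds are considered here, and "the series" means these few. Any claim that something is new, unique, unknown or untested is made for them only; others in the source may bear on it.

Working notes on the series, read for now in a physicochemical assay for lipophilicity, at pH 7.4 (a higher number here means a more lipophilic compound, a lower number a more polar compound), only. Compound 1 (`CC(C)CN(c1cccc(F)c1)S(=O)(=O)c1ccc2c(c1)C(=O)CC(C1CCOCC1)O2`) gives 3.5 as the lowest of the three numbers in hand. Compound 2 (`CCc1ccc(N(CC(C)C)S(=O)(=O)c2ccc(OCC3CCOCC3)c3c2CCC3=O)cc1`) gives 4.44 and stands nearest to compound 1, though the gap lies beyond the scatter. Compound 3 (`CCc1ccc(N(CC(C)C)S(=O)(=O)c2ccc3c(c2)C(=O)CC(C2CCN(S(=O)(=O)C4CCCC4)CC2)O3)cc1`) gives 4.75 and stands furthest from compound 1, also beyond the scatter.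

Within the data shown here, no two measured compounds differ in one place only, so the series offers no measured step to carry over. Compound 4 (`CC(C)CN(c1cc2ccccc2s1)S(=O)(=O)c1ccc2c(c1)C(=O)CC(C1CCOCC1)O2`) keeps the shared core of compound 1 and changes one group: 1-benzothiophen-2-yl in place of 3-fluorophenyl on a sulfonamide nitrogen. The expectation therefore rests on this structural change, starting from compound 1 at 3.5 as the only fixed point. Compound 2 at 4.44 and compound 3 at 4.75 show only that numbers of that height occur among these three compounds. The expected step is upward and beyond the scatter, an estimated a number 0.80 log units higher from compound 1 to compound 4 (beyond the scatter) for this exchange of groups. Compound 4 is expected at 4.3 with an estimated range from 3.9 to 4.8 in this assay once measured.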

Compound 4, distribution coefficient: 4.01
Estimate against measurement, compound 4: 0.29 log units above; the range from low to high includes it.
By their numbers in this assay, from the lowest: compound 1; then compound 4; then compound 2; then compound 3.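

Among these compounds, this is the first measured one-place step: with the shared core and the saturated chain on the sulfonamide nitrogen held fixed, 1-benzothiophen-2-yl in place of 3-fluorophenyl gives a number 0.51 log units higher from compound 1 to compound 4 (beyond the scatter) in this assay, so the number does move with the aromatic group at this position. The exchange alters several things at once, as the fluorine leaves, the heavy-atom count rises, and a five-membered aromatic ring with 1 hetero atom enters alongside the six-membered aromatic ring, so this single step cannot divide its size among those differences. No measured evidence is available to explain the step in this assay.

Among the compounds shown here, with only one exchange at this position, it remains open whether a plain phenyl, or a phenyl ring carrying an amine or a carboxylic acid, would move the number in the same direction. On these data alone, it also remains open whether the same exchange would give a step of similar size on the other cores, such as that of compound 2 or compound 3.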